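The compounds below may be only part of what the source reports. "The series", "measured", "known", "first", "only" and "open" are said of these compounds alone.

Measured so far:
compound 1, `COC(c1cc(Cl)c2c(c1Cl)C(=O)N(Cc1c(C)cc(C)[nH]c1=O)CC2)C1CCOCC1`: 130 uL/min; 129 uL/min (2 entries)
compound 2, `Cc1cc(C)c(CN2CCc3c(Cl)cc([C@@H](C)CO)c(Cl)c3C2=O)c(=O)[nH]1`: 12.4 uL/min

In an ADME assay on microsomes from liver (Homo sapiens) for metabolic stability, read by LC-MS, using NADPH, with stated times of 10 min and 45 min, tested at 1 uM (a higher number here means faster removal of the compound, a lower number slower removal), compound 2 gives 12.4 uL/min, the only number shown for it; one further entry for compound 2 gives no single number. Compound 1 in this assay gives 130 uL/min; 129 uL/min (2 entries), and the repeated entries agree with each other (the several entries of compound 1 in this assay, 130 uL/min; 129 uL/min (2 entries)). Among the compounds with values here, no step between compounds that differ in one place is available in this assay, so compound 2 is the only anchor for the change to compound 3, `Cc1cc(C)c(CN2CCc3c(Cl)cc([C@@H](CO)[C@H]4CCCO4)c(Cl)c3C2=O)c(=O)[nH]1`, which is not yet measured. Compound 3 differs from compound 2 as follows: a group of 8 heavy atoms (6 carbon, 2 oxygen; one five-membered non-aromatic ring with 1 hetero atom) in place of a group of 4 heavy atoms (3 carbon, 1 oxygen; no ring), on an aromatic carbon. Within the data shown here, no measured step guides this change; the expectation is a modest shift towards faster removal in this assay, possibly reaching beyond the usual scatter, though a result within the scatter of compound 2 cannot be excluded. Compound 3 is expected to give 30 uL/min in this assay, between 12 uL/min and 75 uL/min. This estimate means a step of a 2.4-fold higher number from compound 2 to compound 3 (0.38 log units; beyond the scatter) in this assay.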

Compound 3, intrinsic clearance in a liver preparation (reported as CLH), per the amount of preparation that the assay uses in the liver assay: 43 uL/min
Compound 3: middle estimate off by 1.4-fold (0.16 log units), on the low side, within the range that was stated.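

In the liver assay, the group with one five-membered non-aromatic ring in place of 1-(hydroxymethyl)ethyl on this aromatic carbon gives a 3.5-fold higher number from compound 2 to compound 3 (0.54 log units; beyond the scatter), so this position responds to the change. In a physicochemical assay for lipophilicity, at pH 7.4 (on this read-out higher numbers stand for higher lipophilicity and lower numbers for lower lipophilicity), compound 2 gives 2.5 and compound 3 gives 2.5, which is no change at the digits printed from compound 2 to compound 3 (within the scatter), so the faster removal comes with no separation on that read-out. The step in the liver assay is read in an assay whose repeated entries agree closely: the several entries of compound 1 in the liver assay, 130 uL/min; 129 uL/min (2 entries)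

As far as these compounds go, a single pair cannot tell whether the ring, its oxygen or the larger group as a whole carries the step, and the cause stays unknown. From the compounds shown here alone, how an amine or a carboxylic acid on this aromatic carbon would read on either measure remains open.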